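Chlorophenyl to Pyridyl: Expected Cytotoxicity of Compound 3

This account rests on a few compounds, and the source may have more. Where it says the series, first, only, none or still open, it means among the compounds named here.

Of the compounds shown here, two from one series have been tested in an ADME assay on Huh-7 cells (Homo sapiens) for cytotoxicity, with a stated time of 72 h; on this read-out lower numbers stand for higher toxicity in this test and higher numbers for lower toxicity in this test. Compound 1 `CC(C)CCN1C(=O)C(C2=NS(=O)(=O)c3cc(NS(C)(=O)=O)ccc3N2)=C(O)[C@H]2CCC[C@H]21` reaches only a limit there: in this assay compound 1 gives > 1000 nM, a limit rather than a measured number. Compound 2 `CS(=O)(=O)Nc1ccc2c(c1)S(=O)(=O)N=C(C1=C(O)C3CCCC3N(Cc3ccc(Cl)cc3)C1=O)N2` likewise reaches only a limit: in this assay compound 2 gives > 10000 nM, again a limit and not a number. Among the compounds with values here, with the limit of > 1000 nM in this assay, at which 1 of the 2 values shown sits, and the limit of > 10000 nM in this assay, at which 1 of the 2 values shown sits, as the only information, no step between compound 1 and compound 2 can be sized. Compound 3 `CS(=O)(=O)Nc1ccc2c(c1)S(=O)(=O)N=C(C1=C(O)C3CCCC3N(Cc3ccccn3)C1=O)N2` has not yet been measured. It differs from compound 2 by pyridin-2-yl in place of 4-chlorophenyl on a saturated chain carbon bound to an amide-type nitrogen in a ring. Since compound 2 stands at the limit of > 10000 nM in this assay, at which 1 of the 2 values shown sits, the step that the limit leaves unreadable from compound 2 to compound 3 is expected to be none beyond the scatter. Compound 3 is accordingly estimated at 15000 nM, within a range of 5000 nM to 50000 nM, and the assay is expected to report a limit for compound 3 once more.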

Compound 3, half-maximal cytotoxic concentration: > 33000 nM
Compound 3 ended at the assay's limit (the forecaster's own chance of this, stated with the estimate: 85%); middle value at least 2.2-fold (0.34 log units) away from the limit.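

Compound 2 and compound 3 both end at limits in this assay rather than at numbers, so the step between them cannot be read. Still open, going by these compounds, is whether pyridin-2-yl in place of 4-chlorophenyl changes cytotoxicity at all, and by how much.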